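From ethoxycarbonyl to methylsulfonyl in compound 4

This account rests on a few compounds, and the source may have more. Where it says the series, first, only, none or still open, it means among the compounds named here.

For the measured compounds named here, in a functional assay on blood (Homo sapiens) for inhibition (on this read-out higher numbers stand for weaker inhibition and lower numbers for stronger inhibition), compound 3 (`CCOC(=O)CCCOc1ccc(OCc2ccc3ccccc3n2)cc1C1(c2ccccc2)CC2CCC1C2`) gives 150 nM as its single reading. Going by the values given here, compound 2 (`COC(=O)COc1ccc(OCc2ccc3ccccc3n2)cc1C1(c2ccccc2)CC2CCC1C2`) gives 290 nM as its single reading, and the two values lie within the scatter of each other. Compound 1 (`O=C(Nc1cccnc1)Oc1ccc(OCc2nc3ccccc3s2)cc1C1(c2ccccc2)CC2CCC1C2`) differs from both in more than one place and gives 37 nM; 86 nM; 33 nM (3 entries) across its repeats. Those repeats serve as a yardstick, since the several entries of compound 1 in this assay, 37 nM; 86 nM; 33 nM (3 entries) show how far readings of one compound can lie apart.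

Compound 4 (`CS(=O)(=O)CCOc1ccc(OCc2ccc3ccccc3n2)cc1C1(c2ccccc2)CC2CCC1C2`) carries methylsulfonyl in place of (ethoxycarbonyl)methyl on a saturated chain carbon, two bonds along the chain from an oxygen on an aromatic ring. The same difference can be read as 3-(ethoxycarbonyl)propoxy to 2-(methylsulfonyl)ethoxy.

Among the compounds with values here, only one measured step touches this part of the molecule, namely a 1.9-fold lower number from compound 2 to compound 3 (0.29 log units; within the scatter) and it stayed small. Within the data shown here, no measured compound in this set carries methylsulfonyl, so that step offers only indirect guidance and the range must stay wide. The estimated step is a 1.2-fold higher number from compound 3 to compound 4 (0.08 log units; within the scatter) and no change beyond the scatter is expected in this assay on this basis. For compound 4 the estimate is 180 nM with an expected range from 60 nM to 500 nM in this measurement.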

Compound 4, half-maximal inhibitory concentration: 114 nM
Beside the measured number, compound 4's estimate is 1.6-fold (0.20 log units) above it; the range from low to high includes it.
By their numbers in this assay, from the lowest: compounds 4, 3 and 2 (each within the scatter of the next, the first and the last beyond it).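

In this assay, the chain on the oxygen accepts methylsulfonyl in place of (ethoxycarbonyl)methyl with only a 1.3-fold lower number from compound 3 to compound 4 (0.12 log units; within the scatter), so in this pair the ester group is not needed to keep the number in this range. The wider comparison gives a 2.5-fold lower number from compound 2 to compound 4 (0.41 log units; beyond the scatter), the first step around this position to pass beyond the scatter, although it remains modest and compound 3 lies within the scatter of both neighbouring compounds, so the three compounds do not establish a graded trend. The step from compound 3 to compound 4 is also small beside the spread that repeat readings of a single compound can show: the several entries of compound 1 in this assay, 37 nM; 86 nM; 33 nM (3 entries)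

As far as these compounds go, it remains open whether a carboxylic acid or an amine at the end of this chain would stay in the same range, and whether a longer chain bearing methylsulfonyl would do so. From the compounds shown here alone, it is also open whether 2-(methylsulfonyl)ethoxy would give a similar number on the core of compound 1, which differs from compound 4 in more than one place.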